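A few compounds are considered here, and "the series" means these few. Any claim that something is new, unique, unknown or untested is made for them only; others in the source may bear on it.

Compound 1 `CC#CCn1c(N2CCC[C@@H](N)C2)nc2c1c(=O)n(Cc1cc(Cl)ccc1C(=O)O)c(=O)n2C`: > 100000 nM, a limit of the assay.
Compound 2 `CC#CCn1c(N2CCC[C@@H](N)C2)nc2c1c(=O)n(Cc1cccc(F)c1C(=O)O)c(=O)n2C`: > 100000 nM, a limit of the assay.
Compound 3 `CC#CCn1c(N2CCC[C@@H](N)C2)nc2c1c(=O)n(Cc1ccccc1C(=O)O)c(=O)n2C`: > 100000 nM, a limit of the assay.

In an ADME assay on isolated protein for inhibition of Dipeptidyl peptidase 9 (Homo sapiens), with stated times of 15 min, 60 s and 20 min (on this read-out higher numbers stand for weaker inhibition and lower numbers for stronger inhibition), compound 3 sits at the limit of the assay. The two other compounds sit at the same limit, so that the limit of > 100000 nM in this assay, at which 3 of the 3 values shown sit, holds for every measured value shown. The steps between them, a step that the two limits leave unreadable from compound 1 to compound 2, a step that the two limits leave unreadable from compound 1 to compound 3 and a step that the two limits leave unreadable from compound 2 to compound 3, are therefore all unreadable in size and direction, and none of them tells how far any compound lies beyond the limit.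

Compound 4 `CC#CCn1c(N2CCC[C@@H](N)C2)nc2c1c(=O)n(Cc1ccc(Cl)cc1C(=O)OCC)c(=O)n2C` differs from compound 3 in one place: 4-chloro-2-(ethoxycarbonyl)phenyl in place of 2-carboxyphenyl on a saturated chain carbon bound to an aromatic nitrogen. Among the measured compounds shown here, no measured step covers the change from a 2-carboxyphenyl to a 4-chloro-2-(ethoxycarbonyl)phenyl group, and the measured steps give no readable size at all. The expectation for compound 4 therefore rests only on the limit shared by compound 1, compound 2 and compound 3; no step beyond the scatter is expected. In this assay compound 4 is expected to give about 100000 nM, within 30000 nM to 300000 nM, which means an estimated step of a number no higher from compound 3 to compound 4 (the limit leaves the size open).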

Compound 4, half-maximal inhibitory concentration: > 100000 nM
Compound 4: a limit, no number; the forecaster's own chance of this, stated with the estimate: 60%; the middle value sits exactly at the limit.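

In this assay compound 4 gives > 100000 nM, which is a limit of the assay and not a number. The steps joining compound 4 to compound 1, compound 2 and compound 3 therefore cannot be read. The compounds shown leave open how far each lies beyond the limit, and whether any change to the group on the shared core would give a readable number: the limit of > 100000 nM in this assay, at which 4 of the 4 values shown sit.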